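Chloro for methyl on a shared cinnamamide-thiadiazole scaffold

The source may hold more compounds than are shown below. What is called first, only, known or untested is meant among the compounds shown, and "the series" means these compounds.

Compound 1 `Cc1ccc(-c2nnc(NC(=O)/C=C/c3ccc(C(F)(F)F)cc3)s2)cc1` gives 1.1 ug/mL in a functional assay on MCF7 cells (Homo sapiens) for antiproliferative activity, read by MTT assay, with a stated time of 48 h; on this read-out higher numbers stand for weaker inhibition and lower numbers for stronger inhibition. Compound 2 `O=C(/C=C/c1ccc(C(F)(F)F)cc1)Nc1nnc(-c2ccc(Cl)cc2)s1` differs from it by chloro in place of methyl on an aromatic carbon, and this change made a step of a 1.5-fold higher number from compound 1 to compound 2 (0.18 log units; within the scatter). Compound 3 `Cc1ccc(-c2nnc(NC(=O)/C=C/c3ccc(F)cc3)s2)cc1` differs from compound 1 by fluoro in place of trifluoromethyl on an aromatic carbon; in this assay compound 3 gives 1.27 ug/mL, and compound 2 gives 1.65 ug/mL. Compound 4 `O=C(/C=C/c1ccc(F)cc1)Nc1nnc(-c2ccc(Cl)cc2)s1` is not yet measured; it differs from compound 3 by chloro in place of methyl on an aromatic carbon, the same change already seen from compound 1 to compound 2, at the same place. Because that earlier step was a 1.5-fold higher number from compound 1 to compound 2 (0.18 log units; within the scatter), the step from compound 3 to compound 4 in this assay is expected to be a 1.4-fold higher number from compound 3 to compound 4 (0.15 log units; within the scatter). For compound 4 the estimated value is 1.8 ug/mL, expected to lie between 1 ug/mL and 3.5 ug/mL.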

Compound 4, half-maximal inhibitory concentration: 1.58 ug/mL
Compound 4: the middle estimate sits 1.1-fold (0.06 log units) above what was measured; low and high end bracket the measured number.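

In this assay, chloro in place of methyl carried from one core to the other with no difference that can be read: the same change on two cores in this assay, a 1.5-fold higher number (0.18 log units; within the scatter) from compound 1 to compound 2 and a 1.2-fold higher number (0.09 log units; within the scatter) from compound 3 to compound 4, 1.2-fold (0.08 log units) apart, within the scatter of two such steps

Fluoro in place of trifluoromethyl did the same: the same change on two cores in this assay, a 1.2-fold higher number (0.06 log units; within the scatter) from compound 1 to compound 3 and a 1.0-fold lower number (0.02 log units; within the scatter) from compound 2 to compound 4, 1.2-fold (0.08 log units) apart, within the scatter of two such steps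

Yet the new steps, a 1.2-fold higher number from compound 3 to compound 4 (0.09 log units; within the scatter) and a 1.0-fold lower number from compound 2 to compound 4 (0.02 log units; within the scatter), are small, and this agreement shows only that neither change moved the number on either core, not that a change with a real effect would carry over in the same way.

The compounds shown leave open whether an amine, a carboxylic acid or a methoxy group in place of the methyl or the fluoro would behave as these groups do. They also leave open whether these steps hold on other cell lines.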